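The compounds below may be only part of what the source reports. "The series", "measured", "known", "first", "only" and "open" are said of these compounds alone.

Of the compounds shown here, three sharing one core have been measured in an ADME assay on microsomes from liver (Mus musculus) for metabolic stability; a lower number here means that the compound disappears faster, a higher number that the compound lasts longer. Compound 1 `CC(C)C(Cc1ncc[nH]1)c1ccc(-c2ccc3cccc(F)c3c2)[nH]c1=O` reads < 0.0667 h, which is a limit of the assay and not a number. Compound 2 `CC(C)C(c1ncco1)c1ccc(-c2ccc3cccc(F)c3c2)[nH]c1=O` gives 0.08 h, while compound 3 `CC(C)C(c1ccc(-c2ccc3cccc(F)c3c2)[nH]c1=O)N1CCN/C1=N\C#N` gives 0.207 h, the highest number of the set. Compound 4 `CC(C)C(Nc1nccs1)c1ccc(-c2ccc3cccc(F)c3c2)[nH]c1=O` differs from it thus: a group of 6 heavy atoms (3 carbon, 2 nitrogen, 1 sulfur; one five-membered aromatic ring with 2 hetero atoms) in place of a group of 8 heavy atoms (4 carbon, 4 nitrogen; one five-membered non-aromatic ring with 2 hetero atoms), on a saturated chain carbon bound to an aromatic carbon and a saturated chain carbon. Compounds 1 and 2 also carry a five-membered aromatic ring at this place, and both lie lower, as shown by an at least 3.1-fold higher number from compound 1 to compound 3 (0.49 log units; beyond the scatter) and by a 2.6-fold higher number from compound 2 to compound 3 (0.41 log units; beyond the scatter). Both steps are modest in size, so a drop of similar size is expected here: a 2.2-fold lower number from compound 3 to compound 4 (0.34 log units; beyond the scatter). For compound 4 the estimated half-life is 0.095 h, with an expected range from 0.055 h to 0.2 h.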

Compound 4, half-life: 0.0733 h
For compound 4 the middle estimate is 1.3-fold (0.11 log units) above the measured one; low and high end bracket the measured number.
By their numbers in this assay, from the lowest: compounds 4 and 2 (each within the scatter of the next); then compound 3. At a limit, below all of these: compound 1.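

At this place, on a saturated chain carbon, (1,3-thiazol-2-yl)amino gives a 2.8-fold lower number from compound 3 to compound 4 (0.45 log units; beyond the scatter) in this assay, so this aromatic ring also falls short of the non-aromatic ring of compound 3. Exchanging 1,3-oxazol-2-yl for (1,3-thiazol-2-yl)amino gives a 1.1-fold lower number from compound 2 to compound 4 (0.04 log units; within the scatter), so these two groups cannot be told apart here. Compound 1 reads a limit and not a number, and an at least 1.0-fold higher number from compound 1 to compound 4 (0.04 log units; that floor lies within the scatter) is only a floor: the limit of < 0.0667 h in this assay, at which 1 of the 4 values shown sits.

From the compounds shown here alone, whether the higher number of compound 3 depends on its nitrile or on its non-aromatic ring stays open. So does how a simple amine or a carboxylic acid at this place would read in this assay.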